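The source may report more compounds than this note shows. Statements on the series, on what has been measured and on what is new or still open speak of the compounds shown alone.

Measured compounds in a functional assay on B16-F0 cells (Mus musculus) for inhibition, read by CCK-8 assay, with a stated time of 48 h; on this read-out higher numbers stand for weaker inhibition and lower numbers for stronger inhibition:
Compound 1 `COc1cc(-c2ccnc3cc(-c4ccc(Cl)cc4)nn23)cc(OC)c1OC` gives 4090 nM in this assay.
Compound 2 `COc1cc(-c2ccnc3cc(-c4ccc(C(C)(C)C)cc4)nn23)cc(OC)c1OC` gives only a limit of the assay in this assay, > 10000 nM.
Compound 3 `COc1cc(-c2ccnc3cc(-c4c[nH]c5ccccc45)nn23)cc(OC)c1OC` gives 40 nM in this assay.

Compound 3 has the lowest number of the two that are numbers; the nearest is compound 1, and that distance is a 100-fold lower number from compound 1 to compound 3 (2.01 log units; beyond the scatter). The reading for compound 2 is a limit, (the limit of > 10000 nM in this assay, at which 1 of the 3 values shown sits), so compound 3 stands apart from it by an at least 250-fold lower number from compound 2 to compound 3 (2.39 log units; beyond the scatter), and compound 2 stands apart from compound 1 by an at least 2.4-fold higher number from compound 1 to compound 2 (0.38 log units; beyond the scatter).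

Compound 4 `COc1cc(-c2ccnc3cc(-c4cn(C(=O)OC(C)(C)C)c5ccccc45)nn23)cc(OC)c1OC` is not yet measured. It differs from compound 3 by tert-butoxycarbonyl in place of hydrogen on an aromatic nitrogen. None of the three measured steps touches this position: all of them exchange the whole aryl group on the shared core, so they give no direct guide to the size or direction of this change. Among the compounds with values here, the only step that adds a tert-butyl-bearing group, the one from compound 1 to compound 2, sits on a different ring and worsened the number.

The step is therefore expected to be modest and toward a higher number, a 5.0-fold higher number from compound 3 to compound 4 (0.70 log units; beyond the scatter). Compound 4 is estimated at 200 nM, within 50 nM to 1500 nM.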

Compound 4, half-maximal inhibitory concentration: 3070 nM
The estimate for compound 4 lay 15-fold (1.19 log units) below the measured number; the whole stated range lies below it.
By their numbers in this assay, from the lowest: compound 3; then compounds 4 and 1 (each within the scatter of the next). At a limit, above all of these: compound 2.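

Within the data shown here, the earlier steps exchanged the whole aryl group on the shared core, and they showed only that the 1H-indol-3-yl group gave the lowest number. With that group kept, the reading in this assay still depends strongly on what sits on its aromatic nitrogen, with a 77-fold higher number from compound 3 to compound 4 (1.89 log units; beyond the scatter) on this single change. The low number of compound 3 is therefore not held by the 1H-indol-3-yl group whatever its nitrogen carries, although nothing measured here accounts for the size of the step.

From the compounds shown here alone, only hydrogen and tert-butoxycarbonyl appear on this nitrogen, so it remains open how a methyl, an acetyl or a longer chain ending in an amine would read there. Also open, going by these compounds, is whether any group on this nitrogen can keep the number near that of compound 3.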